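This account rests on a few compounds, and the source may have more. Where it says the series, first, only, none or still open, it means among the compounds named here.

Within the data shown here, compound 1 `O=C(Nc1ccccc1C(F)(F)F)C1CCc2ccccc2N1C(=O)c1cccc(Cl)c1` is one of two compounds measured in a functional assay on HCT-15 cells (Homo sapiens) for cytotoxicity, read by sulforhodamine B assay, with a stated time of 72 h (on this read-out lower numbers stand for stronger inhibition of growth and higher numbers for weaker inhibition of growth), where compound 1 gives 797 nM. Its companion, compound 2 `O=C(Nc1ccccc1C(F)(F)F)C1CCc2ccccc2N1C(=O)c1ccc(Cl)cc1`, gives 839 nM in this assay. The two sit together, separated only by a 1.1-fold higher number from compound 1 to compound 2 (0.02 log units; within the scatter), so neither number can be set apart from the other on this read-out.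

The next compound, compound 3 `O=C(Nc1ccccc1O)C1CCc2ccccc2N1C(=O)c1cccc(Cl)c1`, is reached from compound 1 by a single change: hydroxy in place of trifluoromethyl on an aromatic carbon. Among the measured compounds shown here, no measured step speaks to this change. For the measured compounds named here, the one step recorded, a 1.1-fold higher number from compound 1 to compound 2 (0.02 log units; within the scatter), concerns the chlorophenyl on the carbonyl carbon, not the ring that carries the trifluoromethyl, and it was within the scatter in any case. There is thus no measured guide to how the ring bearing the trifluoromethyl answers to a change at that position, and the expectation for compound 3 rests on the value of compound 1 alone, with a wide range around it. In this assay compound 3 is estimated at 1500 nM, expected to lie between 500 nM and 5000 nM. That estimate means an expected step of a 1.9-fold higher number from compound 1 to compound 3 (0.27 log units; within the scatter).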

Compound 3, concentration for 50% growth inhibition: 23100 nM
The estimate for compound 3 lay 15-fold (1.19 log units) below the measured number; measured number outside the range, above it.
By their numbers in this assay, from the lowest: compounds 1 and 2 (each within the scatter of the next); then compound 3.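

Among these compounds, the ring that carries the trifluoromethyl proved far more sensitive than the earlier compounds could show: in this assay the change to hydroxy gives a 29-fold higher number from compound 1 to compound 3 (1.46 log units; beyond the scatter) and so moves the number well beyond the scatter. The only earlier step, a 1.1-fold higher number from compound 1 to compound 2 (0.02 log units; within the scatter) on the chlorophenyl of the carbonyl, had shown no such movement, so this aromatic carbon ortho to a large group is the first place in the series where a single change is seen to weaken growth inhibition markedly. Nothing available bears on why this exchange has so large an effect and the result itself records only that hydroxy at this place goes with much weaker inhibition of growth than trifluoromethyl.

The compounds shown leave open whether a methoxy, an amine or a chlorine at this place would read close to compound 1 or close to compound 3, and so whether the result is specific to hydroxy or reflects the loss of trifluoromethyl. They also leave open whether the same exchange would have as large an effect on the 4-chlorophenyl amide compound 2.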